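Working notes: from compound 1 to compound 4

A few compounds are considered here, and "the series" means these few. Any claim that something is new, unique, unknown or untested is made for them only; others in the source may bear on it.

Measured in a functional assay on PC-3 cells (Homo sapiens) for inhibition, read by sulforhodamine B assay, with a stated time of 48 h; on this read-out lower numbers stand for stronger inhibition of growth and higher numbers for weaker inhibition of growth:
compound 1 `CCOC(=O)C1=C(C)NC(=O)NC1c1ccc(SC)cc1` gives 9.5 ug/mL
compound 2 `CCOC(=O)C1=C(C)NC(=S)NC1c1ccc(O)cc1` gives 47.6 ug/mL
compound 3 `CCOC(=O)C1=C(C)NC(=S)NC1c1ccc(F)cc1` gives 1.7 ug/mL

Compound 1 stands second highest of the three numbers: compound 2 sits at a higher number and compound 3 at a lower one, both gaps beyond the scatter. Going by the values given here, the only single-place step among the measured compounds is a 28-fold lower number from compound 2 to compound 3 (1.45 log units; beyond the scatter); compound 2 and compound 3 also differ from compound 1 elsewhere in the shared core. Compound 4 `CCCc1ccc(C2NC(=O)NC(C)=C2C(=O)OCC)cc1` differs from compound 1 by propyl in place of methylsulfanyl on an aromatic carbon. Among the compounds with values here, no measured step bears on this change. In this assay compound 4 is therefore expected near compound 1, estimated at 8 ug/mL with a range from 3 ug/mL to 25 ug/mL. The expected step, a 1.2-fold lower number from compound 1 to compound 4 (0.07 log units; within the scatter), is none beyond the scatter.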

Compound 4, concentration for 50% growth inhibition: 25 ug/mL
Compound 4: middle estimate off by 3.1-fold (0.49 log units), on the low side, within the range that was stated.
By their numbers in this assay, from the lowest: compound 3; then compound 1; then compounds 4 and 2 (each within the scatter of the next).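

In this assay, propyl in place of methylsulfanyl on this aromatic carbon gives a 2.6-fold higher number from compound 1 to compound 4 (0.42 log units; beyond the scatter), so the two groups are not interchangeable here and growth inhibition weakens modestly. Going by these compounds alone, this is the first single-place step on the core of compound 1; the earlier step belongs to a different core. No supporting measurement accounts for this step.

Still open, as far as these compounds go, is how an amine, a carboxylic acid or a longer chain on this aromatic carbon would read. Also open, from the compounds shown here alone, is whether the same change would carry over to the core of compound 3.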